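Replacing the pyridin-4-yl group of compound 2

A few compounds are considered here, and "the series" means these few. Any claim that something is new, unique, unknown or untested is made for them only; others in the source may bear on it.

Compound 1 `COc1ncc(-c2ccc3c(c2)N(Cc2ccc(F)cc2)C(=O)CO3)cc1NS(=O)(=O)c1ccc(F)cc1F` gives 4980 nM in a functional assay on MDA-MB-231 cells (Homo sapiens) for antiproliferative activity, read by sulforhodamine B assay, with a stated time of 72 h; on this read-out lower numbers stand for stronger inhibition and higher numbers for weaker inhibition
Compound 2 `CCCCS(=O)(=O)Nc1cc(-c2ccc3c(c2)N(Cc2ccncc2)C(=O)CO3)cnc1OC` gives 37900 nM in this assay

Compound 2 gives the higher number of the two at 37900 nM, against compound 1 at 4980 nM on this read-out. This gap lies beyond the scatter. The change to compound 3 `CCCCS(=O)(=O)Nc1cc(-c2ccc3c(c2)N(CCC(=O)N2CCOCC2)C(=O)CO3)cnc1OC` reads ((morpholin-4-yl)carbonyl)methyl in place of pyridin-4-yl on a saturated chain carbon bound to an amide-type nitrogen in a ring and puts ((morpholin-4-yl)carbonyl)methyl in place of pyridin-4-yl on a saturated chain carbon bound to an amide-type nitrogen in a ring. Among the compounds with values here, no measured pair differs in one place only, so nothing in this assay sizes this change directly. The estimated 1.4-fold lower number from compound 2 to compound 3 (0.13 log units; within the scatter) is expected to stay within the scatter, with no clear direction. Compound 3 is expected at 28000 nM with a range from 8000 nM to 80000 nM in this estimate.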

Compound 3, half-maximal inhibitory concentration: 43800 nM
Beside the measured number, compound 3's estimate is 1.6-fold (0.19 log units) below it, and the stated range covers the measured number.
By their numbers in this assay, from the lowest: compound 1; then compounds 2 and 3 (each within the scatter of the next).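

In this assay, the change on the saturated chain carbon bound to an amide-type nitrogen in a ring gives a 1.2-fold higher number from compound 2 to compound 3 (0.06 log units; within the scatter), which lies within the scatter. Within the data shown here, this is the first one-place comparison at this position, and it shows that ((morpholin-4-yl)carbonyl)methyl and pyridin-4-yl cannot be told apart here, although one brings a six-membered aromatic ring and the other a non-aromatic ring with a carbonyl. Nothing available explains this result.

Going by these compounds, whether an amine, a carboxylic acid or a longer chain at this place would move the number beyond the scatter remains open. Also open, on these data alone, is whether this change would read the same with a different group on the sulfonamide.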